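Working notes: extending the chain of compound 3

This account rests on a few compounds, and the source may have more. Where it says the series, first, only, none or still open, it means among the compounds named here.

Measured so far in a functional assay on PC-3 cells (Homo sapiens) for antiproliferative activity, read by MTT assay, with a stated time of 72 h; on this read-out higher numbers stand for weaker inhibition and lower numbers for stronger inhibition
- compound 1 `CCCCCCCCCCNC[C@@H]1OC[C@H](N)[C@@H]1O` gives 11900 nM
- compound 2 `CCCCCCCCCNC[C@@H]1OC[C@H](N)[C@H]1O` gives 7650 nM
- compound 3 `CCCCCCCNC[C@@H]1OC[C@H](N)[C@H]1O` gives > 128000 nM (a limit)

Compound 3 reads > 128000 nM, which is a limit and not a number (the limit of > 128000 nM in this assay, at which 1 of the 3 values shown sits). Compound 4 (`CCCCCCCCCCNC[C@@H]1OC[C@H](N)[C@H]1O`) differs from compound 3 by the change (propyl in place of hydrogen on a saturated chain carbon, seven bonds along the chain from an amine nitrogen), that is, propyl in place of hydrogen on a saturated chain carbon, seven bonds along the chain from an amine nitrogen.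

Going by the values given here, one measured step bears directly on this change: an at least 16-fold higher number from compound 2 to compound 3 (1.22 log units; beyond the scatter), a large step with hydrogen in place of ethyl at that place. Propyl entering there reverses that kind of change, so a large step to a lower number is expected in this assay. Compound 1 at 11900 nM and compound 2 at 7650 nM lie within the usual scatter of each other, and they mark the expected region.

The expected step is an at least 16-fold lower number from compound 3 to compound 4 (1.20 log units; beyond the scatter), and it is an estimate only. For compound 4 the estimate is 8000 nM, with an expected range from 3000 nM to 20000 nM.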

Compound 4, half-maximal inhibitory concentration: > 128000 nM
Compound 4: a limit, no number; the forecaster's own chance of this, stated with the estimate: 5%; at least 16-fold (1.20 log units) between middle value and limit.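

In this assay compound 4 gives > 128000 nM, a limit and not a number, and the step to it from compound 3 cannot be read: the limit of > 128000 nM in this assay, at which 2 of the 4 values shown sit.

The chain does not act in one direction at this place, since the longer chain also gives a large change, with an at least 16-fold higher number from compound 2 to compound 4 (1.22 log units; beyond the scatter). Chain length is also not the only variable that matters, as there is an at least 10-fold higher number from compound 1 to compound 4 (1.03 log units; beyond the scatter), tied to the configuration drawn at a saturated ring carbon: the fact that compounds 1 and 4 differ only in the configuration as drawn

The compounds shown leave open how shorter or longer chains behave with the configuration of compound 1, as only one chain carries it here. Also open, going by these compounds, is whether a phenyl group or a carboxylic acid on the chain would give a number in this assay.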